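A few compounds are considered here, and "the series" means these few. Any claim that something is new, unique, unknown or untested is made for them only; others in the source may bear on it.

Compound 1 `[O-]/[N+](=C\c1cn(-c2ccccc2)nn1)c1ccccc1` gives > 100000 nM in a functional assay on MDA-MB-231 cells (Homo sapiens) for inhibition, read by MTT assay, with a stated time of 24 h (on this read-out higher numbers stand for weaker inhibition and lower numbers for stronger inhibition), a limit.
Compound 2 `[O-]/[N+](=C\c1cn(-c2ccc(Cl)cc2)nn1)c1ccccc1` gives 8900 nM in this assay.
Compound 3 `[O-]/[N+](=C\c1cn(-c2ccccc2)nn1)Cc1ccccc1` gives > 100000 nM in this assay, a limit.

Compound 3 thus stands at the limit of > 100000 nM in this assay, at which 2 of the 3 values shown sit, reported only as a limit and not as a number. Compound 4 `COc1ccc(-n2cc(/C=[N+](\[O-])Cc3ccccc3)nn2)cc1` differs from it by methoxy in place of hydrogen on an aromatic carbon. Of the measured steps, an at least 11-fold lower number from compound 1 to compound 2 (1.05 log units; beyond the scatter) is the one that bears on this change; it also placed a group on an aromatic carbon of the same ring. a step that the two limits leave unreadable from compound 1 to compound 3 is not readable. A methoxy is not a chloro, and compound 3 sits at a limit, so the size is uncertain, though a lowering of the number is expected. The step from compound 3 to compound 4 is estimated at an at least 3.3-fold lower number from compound 3 to compound 4 (0.52 log units; beyond the scatter). Compound 4 is therefore expected to give about 30000 nM, within 5000 nM to 150000 nM.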

Compound 4, half-maximal inhibitory concentration: > 100000 nM
Compound 4 ended at the assay's limit; the forecaster's own chance of this, stated with the estimate: 45%; middle value at least 3.3-fold (0.52 log units) away from the limit.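

Compound 3 and compound 4 both sit at the assay's limit, so no step can be read between them: the limit of > 100000 nM in this assay, at which 3 of the 4 values shown sit.

The compounds shown leave open whether methoxy in place of hydrogen on an aromatic carbon changes the read-out at all.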